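Chloro for Fluoro on the Phenoxy Ring

The compounds below may be only part of what the source reports. "The series", "measured", "known", "first", "only" and "open" are said of these compounds alone.

Measured compounds:
- compound 1, `CN1CCN(c2ccc(S(=O)(=O)Oc3ccc(F)cc3)cc2)C1=O`: > 100000 nM
- compound 2, `CN1CCN(c2ccc(S(=O)(=O)Oc3ccc(Cl)cc3)cc2)C1=O`: 43000 nM
- compound 3, `CCN1CCN(c2ccc(S(=O)(=O)Oc3cccc(F)c3)cc2)C1=O`: 11000 nM

All three were tested in a functional assay on M21 cells (Homo sapiens) for antiproliferative activity, read by sulforhodamine B assay, with a stated time of 48 h; on this read-out lower numbers stand for stronger inhibition and higher numbers for weaker inhibition. For compound 1 the result > 100000 nM is a limit of the assay and not a number; it sits at the limit of > 100000 nM in this assay, at which 1 of the 3 values shown sits. Compound 2 gives 43000 nM in this assay, and compound 3 gives 11000 nM, the lowest of the two numbers.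

Compound 1 and compound 2 differ in one place: chloro in place of fluoro on an aromatic carbon. That change brought an at least 2.3-fold lower number from compound 1 to compound 2 (0.36 log units; beyond the scatter). Compound 3 carries a different core from compound 1; how the two cores differ is not broken down here.

Compound 4, `CCN1CCN(c2ccc(S(=O)(=O)Oc3cccc(Cl)c3)cc2)C1=O`, is not yet measured. It stands to compound 3 as compound 2 stands to compound 1: chloro in place of fluoro on an aromatic carbon. The place is not the same word for word: in compound 2 the chloro sits para to a large group, in compound 4 it sits meta to a large group, so this is the same kind of change rather than the same change. Among the compounds with values here, the step from compound 1 to compound 2 is the only guide to its size, and it was at least modest. On that basis compound 4 is expected to show a 2.8-fold lower number from compound 3 to compound 4 (0.44 log units; beyond the scatter) in this assay, giving an estimated 4000 nM, likely between 1500 nM and 15000 nM.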

Compound 4, half-maximal inhibitory concentration: 3900 nM
Estimate against measurement, compound 4: 1.0-fold (0.01 log units) above; the measured number falls inside the stated range.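

In this assay, putting chloro in place of fluoro, here 3-fluorophenoxy to 3-chlorophenoxy, gave a 2.8-fold lower number from compound 3 to compound 4 (0.45 log units; beyond the scatter), so the swap moved the number in the same direction on a second core. This suggests that the gain seen on the first core carried over to the second, even though the chloro does not sit at the same place on the ring in the two pairs, and the two steps can be set side by side: the same change on two cores in this assay, an at least 2.3-fold lower number (0.36 log units; beyond the scatter) from compound 1 to compound 2 and a 2.8-fold lower number (0.45 log units; beyond the scatter) from compound 3 to compound 4; the limit leaves it open whether they differ

Compound 1 has a limit of the assay and not a number, > 100000 nM, so the first step has no exact size, and two pairs of compounds are too few to make a rule for the whole series.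

The compounds shown leave open whether a bromo or a methoxy group at the same place on the ring would lower the number further than chloro does. They also leave open whether the same swap would hold on a core carrying a longer chain, such as propyl, and whether chloro and fluoro would behave alike at each place on the ring within a single core.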